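This account rests on a few compounds, and the source may have more. Where it says the series, first, only, none or still open, it means among the compounds named here.

Compound 1 `CC(Sc1nnc(-c2ccncc2)s1)C(=O)Nc1ccc(Cl)cc1Cl` and compound 2 `CC(Sc1nnc(-c2ccncc2)s1)C(=O)Nc1ccccc1Cl` share a core and were both tested in an ADME assay on BHK-21 cells (Mesocricetus auratus) for cytotoxicity, with a stated time of 3 days; on this read-out higher numbers stand for lower toxicity in this test and lower numbers for higher toxicity in this test. In this assay compound 1 gives > 50000 nM, which is a limit of the assay rather than a number. Compound 2 gives > 50000 nM, again a limit. The two differ by hydrogen in place of chloro on an aromatic carbon, and the step that the two limits leave unreadable from compound 1 to compound 2 cannot be read because of the limit of > 50000 nM in this assay, at which 2 of the 3 values shown sit. Compound 3 `CC(CSc1nnc(-c2ccncc2)s1)C(=O)NCc1ccc(Cl)cc1` has a core whose difference from that of compound 1 is not broken down here; in this assay compound 3 gives "not determined" (no result reported). Compound 4 `CC(CSc1nnc(-c2ccncc2)s1)C(=O)NCc1ccccc1` differs from compound 3 by hydrogen in place of chloro on an aromatic carbon, the same kind of change as that from compound 1 to compound 2, though there the place was also meta to a chloro group. Both measured values rest on (the limit of > 50000 nM in this assay, at which 2 of the 3 values shown sit), so the step from compound 3 to compound 4 is expected to be small. For compound 4 the expected value in this assay is 80000 nM, estimated to lie between 30000 nM and 300000 nM.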

Compound 4, half-maximal cytotoxic concentration: > 50000 nM
Compound 4: only a limit was reported; the forecaster's own chance of this, stated with the estimate: 85%; the middle value lies beyond the limit too.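

In this assay compound 4 gives > 50000 nM, a limit and not a number. No new step can be read from compound 3 to compound 4. The compounds shown leave open where the half-maximal cytotoxic concentrations of compound 1, compound 2 and compound 4 actually lie.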